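Amide aryl replacement in a maximal-response series

The compounds below may be only part of what the source reports. "The series", "measured", "known", "first", "only" and "open" are said of these compounds alone.

Of the compounds shown here, three sharing one core have been measured in a functional assay on HEK293 cells for agonist activity at D(4) dopamine receptor (Homo sapiens), read by FLIPR; a higher number here means a larger maximal response, a lower number a smaller maximal response. Compound 1 `O=C(CN1CCC(c2cccc[n+]2[O-])CC1)Nc1cccc(Cl)c1Cl` gives 66%. Compound 2 `O=C(CN1CCC(c2cccc[n+]2[O-])CC1)Nc1ccc(F)cc1` gives 71%. Compound 3 `O=C(CN1CCC(c2cccc[n+]2[O-])CC1)Nc1ccccc1F` gives 63%, the lowest of the three numbers, but its nearest neighbour is compound 1 and its furthest is compound 2, and both gaps lie within the scatter, so no order among the three can be read from this assay.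

The step now followed replaces the aryl group on the amide-type nitrogen of compound 3 to give compound 4 `CSc1cccc(NC(=O)CN2CCC(c3cccc[n+]3[O-])CC2)c1`: 3-(methylsulfanyl)phenyl in place of 2-fluorophenyl on an amide-type nitrogen. The measured steps at the same position bear on it: a number 3 percentage points lower from compound 1 to compound 3 (within the scatter) and a number 8 percentage points lower from compound 2 to compound 3 (within the scatter), and likewise a number 5 percentage points higher from compound 1 to compound 2 (within the scatter). Every change of the aryl group at this nitrogen so far has left the maximal response in this assay unmoved beyond the scatter. The expected step of a number 3 percentage points higher from compound 3 to compound 4 (within the scatter) is therefore one with no direction beyond the scatter. Compound 4 is estimated at 66%, with a range from 52% to 80%.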

Compound 4, largest response reached (reported as efficacy), in percent of the reference or control that the assay uses: 56%
For compound 4 the middle estimate is 10 percentage points above the measured one, within the range that was stated.
By their numbers in this assay, from the lowest: compounds 4, 3, 1 and 2 (each within the scatter of the next, the first and the last beyond it).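

In this assay, the aryl group on the amide-type nitrogen now shows one replacement that reaches beyond the scatter: 3-(methylsulfanyl)phenyl in place of 4-fluorophenyl (a number 15 percentage points lower from compound 2 to compound 4 (beyond the scatter)). Against the other two aryl groups, the same group stays within the scatter (a number 7 percentage points lower from compound 3 to compound 4 (within the scatter); a number 10 percentage points lower from compound 1 to compound 4 (within the scatter)), so the position is not wholly silent, but only this one pair of the four compounds separates. Nothing measured here bears on the reason for that separation.

Still open, going by these compounds, is whether the separation belongs to the sulfur-bearing group itself or to where it sits on the ring. Also open, on these data alone, is whether an aryl group carrying an amine or a carboxylic acid, or a longer alkyl chain in place of the aryl group, would move the maximal response further.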